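The source may report more compounds than this note shows. Statements on the series, on what has been measured and on what is new or still open speak of the compounds shown alone.

Measured compounds:
compound 1 `COc1ccc(-c2cnc3nc(N)nc(OC(C)C)c3n2)cc1` — > 10000 nM
compound 2 `CCOc1nc(N)nc2ncc(-c3ccc(C(F)(F)F)cc3)nc12` — 10000 nM
compound 3 `COc1ccc(-c2cnc3nc(N)nc(N4CCN(Cc5ccccc5F)CC4)c3n2)cc1OC` — 700 nM

The read-out throughout is a functional assay on cells (T-cell, Homo sapiens) for inhibition; a lower number here means a stronger inhibitor, a higher number a weaker inhibitor. For compound 1 the value is a limit of the assay and not a number (the limit of > 10000 nM in this assay, at which 1 of the 3 values shown sits). Of the two numbers, compound 2 holds the higher one; compound 3 sits lower, a gap beyond the scatter. Compound 4 `CCOc1nc(N)nc2ncc(-c3ccc(C#N)cc3)nc12` is not yet measured and differs from compound 2 in one place: cyano in place of trifluoromethyl on an aromatic carbon. Among the compounds with values here, no measured pair shows this change, so its size is unknown. The expected step is no change at the digits printed from compound 2 to compound 4 (within the scatter), not beyond the scatter. Compound 4 is thus estimated at 10000 nM, with a range from 3000 nM to 30000 nM; a reading as a limit rather than a number is also possible.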

Compound 4, half-maximal inhibitory concentration: > 10000 nM
Compound 4 ended at the assay's limit (the forecaster's own chance of this, stated with the estimate: 40%); the middle value lies on the limit itself.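

In this assay, within the data shown here, the only one-place comparison, cyano in place of trifluoromethyl on the aromatic carbon para to a large group, gives a number no lower from compound 2 to compound 4 (the limit leaves the size open). Compound 4 gives > 10000 nM, which is a limit of the assay and not a number, so this change brings no readable gain at this position. The limit now bounds a large part of the set: the limit of > 10000 nM in this assay, at which 2 of the 4 values shown sit.

Whether cyano and trifluoromethyl differ at all at this position cannot be read. Also open, on these data alone, is whether an amine or a carboxylic acid at this position would give a readable gain over compound 2.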